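Methyl on the Phenyl Ring: Diaminoquinazoline Dithiocarbamates

The source may hold more compounds than are shown below. What is called first, only, known or untested is meant among the compounds shown, and "the series" means these compounds.

Measured compounds:
compound 1, `CN1CCN(C(=S)SCc2ccc3nc(N)nc(N)c3c2)CC1`, 9200 nM;
compound 2, `Nc1nc(N)c2cc(CSC(=S)N3CCN(c4ccccc4)CC3)ccc2n1`, 2970 nM.

Both were tested in a functional assay on A549 cells (Homo sapiens) for antiproliferative activity, read by MTT assay, with a stated time of 72 h; on this read-out lower numbers stand for stronger inhibition and higher numbers for weaker inhibition. Compound 2 gives the lower of the two numbers in this assay; the step from compound 1 to compound 2, a 3.1-fold lower number from compound 1 to compound 2 (0.49 log units; beyond the scatter), came from placing phenyl in place of methyl on an amine nitrogen in a ring.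

Compound 3, `Cc1ccc(N2CCN(C(=S)SCc3ccc4nc(N)nc(N)c4c3)CC2)cc1`, is not yet measured. It differs from compound 2 by methyl in place of hydrogen on an aromatic carbon, on an aromatic carbon of a six-membered aromatic ring of carbon only, para to a large group.

Among the compounds with values here, no measured step here touches that ring, so the only step available, from compound 1 to compound 2, concerns a different site and bears on compound 3 only loosely. With nothing pointing either way, the step from compound 2 to compound 3 is expected to stay within the scatter, a 1.2-fold lower number from compound 2 to compound 3 (0.07 log units; within the scatter). Compound 3 is therefore estimated at 2500 nM, in the range 1000 nM to 7000 nM.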

Compound 3, half-maximal inhibitory concentration: 2190 nM
Compound 3: middle estimate off by 1.1-fold (0.06 log units), on the high side, within the range that was stated.
By their numbers in this assay, from the lowest: compounds 3 and 2 (each within the scatter of the next); then compound 1.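

In this assay, the methyl group on the aromatic carbon para to a large group gives a 1.4-fold lower number from compound 2 to compound 3 (0.13 log units; within the scatter), so this place on the phenyl ring takes a methyl group with no change that stands clear of the scatter. Against the methyl group on the ring nitrogen, 4-methylphenyl keeps a clear edge, with a 4.2-fold lower number from compound 1 to compound 3 (0.62 log units; beyond the scatter), so the benefit seen with phenyl survives this addition. Nothing measured here gives a reason for either step.

The compounds shown leave open whether a different group at this same place, such as a chlorine atom, a methoxy group or a longer chain, would move the number beyond the scatter. They also leave open whether a methyl group elsewhere on the phenyl ring would behave the same way.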